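Amino for methoxy on the shared core

A few compounds are considered here, and "the series" means these few. Any claim that something is new, unique, unknown or untested is made for them only; others in the source may bear on it.

For the measured compounds named here, compound 1 `COc1nc2ccccc2n1C(=O)NCCCCc1ccccc1` stands lowest of the two numbers measured so far. In an assay on HEK293 cells for inhibition of acid ceramidase (Homo sapiens), read by fluorescence, with stated times of 30 min and 1 h (a higher number here means a weaker inhibitor, a lower number a stronger inhibitor), compound 1 gives 13.9 nM. Its nearest neighbour on the numbers is compound 2 `Cc1ccccc1CNC(=O)n1c(N)nc2ccccc21`; in this assay compound 2 gives 68.4 nM, a gap beyond the usual scatter. Compound 2 differs from compound 1 in more than one place, so the two values show only that the combination of an amino group with the shorter side chain comes out weaker than compound 1; neither change is isolated by them.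

Compound 3 `Nc1nc2ccccc2n1C(=O)NCCCCc1ccccc1` moves one step away from compound 1: amino in place of methoxy on an aromatic carbon. Going by the values given here, no measured pair isolates this change. The only measured carrier of the amino group is compound 2, and its weaker value of 68.4 nM is the one pointer available. A modest loss is expected, at the edge of the scatter rather than clearly beyond it. The expected step is a 2.2-fold higher number from compound 1 to compound 3 (0.33 log units; beyond the scatter), toward a weaker inhibitor. Compound 3 is estimated at 30 nM in this assay, with a range of 9 nM to 100 nM.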

Compound 3, half-maximal inhibitory concentration: 0.9 nM
For compound 3 the middle estimate is 33-fold (1.52 log units) above the measured one; measured number below the stated range.
By their numbers in this assay, from the lowest: compound 3; then compound 1; then compound 2.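

In this assay, amino in place of methoxy on an aromatic carbon gives a 15-fold lower number from compound 1 to compound 3 (1.19 log units; beyond the scatter), a large step toward a stronger inhibitor and the first single change isolated in the series. With the side chain of compound 1 held constant, this position proves highly responsive to the exchange, and the amino group by itself does not cost activity here, so the weaker value of compound 2 cannot be laid on the amino group alone. The exchange brings in a hydrogen-bond donor that methoxy lacks, but nothing at hand ties the step to that difference or to any other.

Still open, as far as these compounds go, is whether the gain needs the free amino group itself: a methylamino or dimethylamino group, or a hydroxyl or methyl group on the same carbon, would help separate the possibilities. For the compounds shown here, also open is whether a step of this size carries over to side chains other than the one shared by compound 1 and compound 3, such as a longer chain or one ending in a substituted phenyl ring.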